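Working notes: the step from compound 3 to compound 4

A few compounds are considered here, and "the series" means these few. Any claim that something is new, unique, unknown or untested is made for them only; others in the source may bear on it.

Measured so far in a functional assay on the whole organism (strain Swiss) with Mus musculus as the target, in the maximal electroshock model, with a stated time of 0.5 h, at a dose of 300 mg/kg by the intraperitoneal route; on this read-out lower numbers stand for a weaker effect and higher numbers for a stronger effect at the one dose given:
compound 1 `CC(C(=O)N1CCN(c2ccccc2)CC1)N1C(=O)CCC1=O` gives 50%
compound 2 `CCC(C(=O)N1CCN(c2cccc(OC)c2)CC1)N1C(=O)CCC1=O` gives 0%
compound 3 `CC(C(=O)N1CCOCC1)N1C(=O)CCC1=O` gives 0%

Compound 3 sits level with compound 2 at the digits reported, and the two share the lowest reading of the three; compound 1 lies higher, beyond the scatter. Going by the values given here, no pair differing in one place has been measured, so no step is known.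

Compound 4 `CCC(C(=O)N1CCOCC1)N1C(=O)CCC1=O` is still unmeasured. It differs from compound 3 thus: methyl in place of hydrogen on a saturated chain carbon, two bonds along the chain from an amide-type nitrogen in a ring and a carbonyl carbon.

Compound 3 gives 0%, and compound 2, which also carries ethyl, gives 0%. Compound 4 is therefore expected to stay low, with a step of a number 8 percentage points higher from compound 3 to compound 4 (within the scatter) that is not beyond the scatter. The estimate for compound 4 is 8%, within 0% to 35%.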

Compound 4, a percentage reported as activity, at one dose (the size of the read-out at that dose, not a potency): 0%
Compound 4: the middle estimate sits 8 percentage points above what was measured; measured number inside the range.
By their numbers in this assay, from the lowest: compounds 2, 3 and 4 (each within the scatter of the next); then compound 1.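

In this assay, going by these compounds alone, methyl in place of hydrogen on this saturated chain carbon gives no change at the digits printed from compound 3 to compound 4 (within the scatter), the first step that can be read. On this core the change therefore brings no gain in effect at the one dose given, though both readings lie at the bottom of the scale. Nothing at hand accounts for this result.

On these data alone, whether a longer chain such as propyl or an amine at this position would raise the reading stays open. As far as these compounds go, the effect of the same change on the core of compound 1 also stays open.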